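A saturated ring replaces the pyridinyl amide in compound 4

The compounds below may be only part of what the source reports. "The series", "measured", "known", "first", "only" and "open" are said of these compounds alone.

Three compounds built on a shared core were examined in an assay on isolated protein for displacement of a labelled ligand from secreted frizzled-related protein 1 (Homo sapiens), read by fluorescence polarization, with a stated time of 30 min; on this read-out lower numbers stand for stronger inhibition and higher numbers for weaker inhibition. Compound 1 `O=C(c1ccccn1)N1CCC(NS(=O)(=O)c2cc(S(=O)(=O)c3ccccc3)ccc2C(F)(F)F)CC1` gives 60 nM in this assay. Compound 2 `O=C(c1ccc(Cl)nc1)N1CCC(NS(=O)(=O)c2cc(S(=O)(=O)c3ccccc3)ccc2C(F)(F)F)CC1` gives 110 nM, and compound 3 `CN(C)c1ccc(C(=O)N2CCC(NS(=O)(=O)c3cc(S(=O)(=O)c4ccccc4)ccc3C(F)(F)F)CC2)cn1` gives 40 nM. Among the measured compounds shown here, compound 3 holds the lowest of the three numbers, although the step of a 1.5-fold lower number from compound 1 to compound 3 (0.18 log units; within the scatter) is within the scatter; only the step of a 2.8-fold lower number from compound 2 to compound 3 (0.44 log units; beyond the scatter) lies beyond it. Compound 4 `CC(C)(C)OC(=O)N1CC[C@@H](C(=O)N2CCC(NS(=O)(=O)c3cc(S(=O)(=O)c4ccccc4)ccc3C(F)(F)F)CC2)C1` has not yet been measured; it differs from compound 3 by 1-(tert-butoxycarbonyl)pyrrolidin-3-yl in place of 6-(dimethylamino)pyridin-3-yl on a carbonyl carbon. The steps measured so far, a 1.8-fold higher number from compound 1 to compound 2 (0.26 log units; within the scatter), a 1.5-fold lower number from compound 1 to compound 3 (0.18 log units; within the scatter) and a 2.8-fold lower number from compound 2 to compound 3 (0.44 log units; beyond the scatter), all vary the aromatic group on that carbonyl carbon and together show that this position moves the number only modestly. For the measured compounds named here, none of them covers an exchange of the aromatic group for a five-membered non-aromatic ring carrying a tert-butoxycarbonyl group, so no direct precedent exists. Leaning on the modest size of those steps, the author expects a modest step towards a higher number for compound 4, a 2.5-fold higher number from compound 3 to compound 4 (0.40 log units; beyond the scatter), in this assay. Compound 4 is accordingly estimated at 100 nM, with a range from 30 nM to 350 nM.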

Compound 4, half-maximal inhibitory concentration: 50 nM
Compound 4: the middle estimate sits 2.0-fold (0.30 log units) above what was measured; the range from low to high includes it.
By their numbers in this assay, from the lowest: compounds 3, 4, 1 and 2 (each within the scatter of the next, the first and the last beyond it).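

In this assay, the place on the carbonyl carbon whose other neighbour is the amide-type nitrogen in a ring proves to tolerate more than a change of substituent on a pyridine: with 1-(tert-butoxycarbonyl)pyrrolidin-3-yl, a five-membered non-aromatic ring, the number stays level with those of the two best aromatic members, as a 1.3-fold higher number from compound 3 to compound 4 (0.10 log units; within the scatter) and a 1.2-fold lower number from compound 1 to compound 4 (0.08 log units; within the scatter) show. Compound 2 alone stands apart, with a 2.2-fold lower number from compound 2 to compound 4 (0.34 log units; beyond the scatter), the same direction as its step to compound 3, so among these four compounds an aromatic ring on the carbonyl carbon is not needed for a number at this level, and the 6-chloropyridin-3-yl compound is the only one that goes against the otherwise flat picture. No measurement at hand accounts for this tolerance.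

As far as these compounds go, it remains open whether the number holds once the tert-butoxycarbonyl group gives way to a free secondary amine on the pyrrolidine ring or to a small acetyl group, and whether the opposite configuration at the defined stereocentre gives the same value. Equally open, from the compounds shown here alone, is how a simple open alkyl chain or a carboxylic acid on that carbonyl carbon would read.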